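This account rests on a few compounds, and the source may have more. Where it says the series, first, only, none or still open, it means among the compounds named here.

Series notes. Going by the values given here, compound 1, `COC(=O)N1CCN([C@H]2CC[C@H](Nc3ncnn4ccc([C@H](C)CC(N)=O)c34)CC2)CC1`, is the one fully quantified member so far: in an ADME assay on cells (Hepatocyte, Homo sapiens) for metabolic stability (on this read-out lower numbers stand for slow clearance and higher numbers for fast clearance), compound 1 gives 3 uL/min. Compound 2, `CC(=O)N1CCN([C@H]2CC[C@H](Nc3ncnn4ccc(C(C)C)c34)CC2)CC1`, shares the core, with an acetyl-bearing piperazine and an isopropyl on the five-membered aromatic ring. For compound 2 this assay returns only a limit, < 1.1 uL/min, so the number for compound 2 is not known, only its bound. That bound is the limit of < 1.1 uL/min in this assay, at which 1 of the 2 values shown sits, which is where compound 2 stands among the two values shown. Among the compounds with values here, no step between measured compounds is available to calibrate the next change.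

Compound 3, `CC(=O)N1CCN([C@H]2CC[C@H](Nc3ncnn4ccc(C5CCOCC5)c34)CC2)CC1`, differs from compound 2 by oxan-4-yl in place of isopropyl on an aromatic carbon. This carries one additional hydrogen-bond acceptor into the same position, in the oxan-4-yl ring. Without a measured step of the same kind, no change beyond the usual scatter is expected from compound 2 to compound 3, an at least 1.0-fold higher number from compound 2 to compound 3 (0.03 log units; that floor lies within the scatter). Compound 3 is therefore expected near 1.2 uL/min, with a likely range of 0.5 uL/min to 3 uL/min, and a real chance that this assay again reports only a limit for compound 3.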

Compound 3, intrinsic clearance in a liver preparation (reported as CLH), per the amount of preparation that the assay uses: 1.2 uL/min
Compound 3: middle estimate and measured number agree at the digits printed; the range from low to high includes it.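

In this assay, oxan-4-yl in place of isopropyl on this aromatic carbon gives an at least 1.0-fold higher number from compound 2 to compound 3 (0.03 log units; that floor lies within the scatter). That is only a floor, and the size of the true step cannot be read from it. Compound 2 enters the step as a limit and not as a number: the limit of < 1.1 uL/min in this assay, at which 1 of the 3 values shown sits. Compound 3 gives 1.2 uL/min, so this position now has its first number with the acetyl-bearing piperazine, and it comes from a group carrying a six-membered non-aromatic ring and a hydrogen-bond acceptor.

From the compounds shown here alone, whether the ring oxygen of oxan-4-yl matters at all remains open, and an all-carbon cyclohexyl at the same place would separate it from the ring itself. Also open, going by these compounds, is how an amine or a carboxylic acid on this carbon would read in this assay.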